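The source may hold more compounds than are shown below. What is called first, only, known or untested is meant among the compounds shown, and "the series" means these compounds.

Compound 1 `CN(c1cccc2c1CCCC2c1c[nH]cn1)S(C)(=O)=O`, compound 2 `O=S(=O)(Nc1cccc2c1CCCC2c1c[nH]cn1)C1CC1` and compound 3 `O=S(=O)(Nc1cccc2c1CCCC2c1c[nH]cn1)c1ccc2ccccc2c1` share one core and differ only in the group carried on the nitrogen attached to the aromatic ring. In an assay on isolated protein (Cricetulus griseus) for binding affinity to Alpha-1B adrenergic receptor (Mesocricetus auratus), read by radioligand binding (a higher number here means a weaker inhibitor, a lower number a stronger inhibitor), compound 1 gives < 10000 nM, which is a limit of the assay and not a number. In this assay compound 2 likewise gives < 10000 nM, again a limit rather than a number. Compound 3 gives 214 nM in this assay. The step that the two limits leave unreadable from compound 1 to compound 2 therefore cannot be read, since both ends sit at the limit of < 10000 nM in this assay, at which 2 of the 3 values shown sit. Compound 2 thus stands only as a limit, with no measured number of its own. Compound 4 `O=C(Nc1cccc2c1CCCC2c1c[nH]cn1)C(F)(F)F` differs from compound 2 by (trifluoromethyl)carbonyl in place of cyclopropylsulfonyl on a nitrogen on an aromatic ring. Among the measured compounds shown here, no measured step bears on this exchange: the one step between measured compounds is unreadable, and compound 3 carries a different group again. The step that the limit leaves unreadable from compound 2 to compound 4 is therefore expected to stay within the scatter, with the direction uncertain. For compound 4 the estimate in this assay is 3000 nM, with a range from 500 nM to 15000 nM.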

Compound 4, inhibition constant: < 10000 nM
Compound 4: a limit, no number; the forecaster's own chance of this, stated with the estimate: 40%; the middle value is on the limit's open side.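

Compound 4 gives < 10000 nM, again a limit of the assay and not a number. The steps from compound 1 and compound 2 to compound 4 therefore cannot be read: the limit of < 10000 nM in this assay, at which 3 of the 4 values shown sit.

The compounds shown leave open whether (trifluoromethyl)carbonyl in place of cyclopropylsulfonyl changes the result in this assay at all.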